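This account rests on a few compounds, and the source may have more. Where it says the series, first, only, none or still open, it means among the compounds named here.

Three compounds have been measured in a functional assay on ACHN cells (Homo sapiens) for inhibition, read by sulforhodamine B assay, tested at 10 uM; a higher number here means more inhibition at the concentration tested (going by the name of the read-out), a lower number less inhibition:

Compound 1, `COc1cc2oc(-c3cccc(NC(=O)c4ccc(Cl)cc4)c3)cc(=O)c2c(OC)c1OC`, gives 51.1%.
Compound 2, `COc1cc2oc(-c3cccc(NC(=O)c4ccc(Br)cc4)c3)cc(=O)c2c(OC)c1OC`, gives 63.6%.
Compound 3, `COc1cc2oc(-c3cccc(C(=O)Nc4ccc(Cl)cc4)c3)cc(=O)c2c(OC)c1OC`, gives 61.4%.

Compound 3 stands second highest of the three numbers. Its value and that of compound 2 lie within the scatter of each other, so no order between them can be read. Against compound 1 the step is real: a number 10.3 percentage points higher from compound 1 to compound 3 (beyond the scatter).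

Compound 4, `COc1cc2oc(-c3cccc(C(=O)Nc4ccc(Cl)cc4)c3)cc(=O)c2c(O)c1OC`, has not been measured. It differs from compound 3 in a single place: hydrogen in place of methyl on an oxygen on an aromatic ring. Read one bond further out, a methoxy becomes a hydroxy on the shared core.

For the measured compounds named here, none of the measured steps touches this part of the molecule. The steps of a number 12.5 percentage points higher from compound 1 to compound 2 (beyond the scatter) and a number 10.3 percentage points higher from compound 1 to compound 3 (beyond the scatter) change the halogen or the direction of the amide, and a number 2.2 percentage points lower from compound 2 to compound 3 (within the scatter) stays within the scatter. Going by the values given here, the data therefore hold no step that bears on the change at hand, and the expectation for this assay is a step of no size beyond the scatter in either direction, with a wide range to allow for the unknown. For compound 4 the estimated value is 56%, between 35% and 77%, which is expected to mean a number 5.4 percentage points lower from compound 3 to compound 4 (within the scatter).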

Compound 4, a percentage reported as inhibition, at one concentration (the size of the read-out at that concentration, not a potency): 53%
The estimate for compound 4 lay 3 percentage points above the measured number, and the stated range covers the measured number.
By their numbers in this assay, from the lowest: compounds 1, 4, 3 and 2 (each within the scatter of the next, the first and the last beyond it).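

Swapping the methoxy for a hydroxy on the shared core gives the first reading at this position in this assay, with a number 8.4 percentage points lower from compound 3 to compound 4 (within the scatter) as the step. At this single concentration, compound 4 and compound 3 cannot be told apart, so in this compound the methyl on this oxygen is not shown to matter for the read-out, though a modest real difference could still lie hidden in the scatter. No measurement shown here offers an explanation for this result.

Going by these compounds, it remains open whether an ethoxy group, a longer chain or an amine at this place would read differently from the methoxy and the hydroxy. The same exchange at the other methoxy groups of the core, or in the bromo compound 2, is also still untested in the compounds shown.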